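The source may report more compounds than this note shows. Statements on the series, on what has been measured and on what is new or still open speak of the compounds shown alone.

Compounds measured so far:
Compound 1 `O=C(Nc1ccc(CN2CCCC2)cc1)Nc1ccc2ncnc(Nc3cccc(C(F)(F)F)c3)c2c1` gives 1360 nM in a functional assay on A-431 cells (Homo sapiens) for antiproliferative activity, read by MTT assay, with a stated time of 72 h; on this read-out higher numbers stand for weaker inhibition and lower numbers for stronger inhibition.
Compound 2 `CN(C)Cc1ccc(NC(=O)Nc2ccc3ncnc(Nc4cccc(C(F)(F)F)c4)c3c2)cc1` gives 1030 nM.
Compound 3 `O=C(Nc1cccc(CN2CCCCC2)c1)Nc1ccc2ncnc(Nc3cccc(C(F)(F)F)c3)c2c1` gives 1330 nM.

Compound 3 stands second highest of these three numbers, yet its gaps to compound 1 and to compound 2 both fall within the scatter, so nothing separates the three. Compound 4 `O=C(Nc1cccc(CN2CCCC2)c1)Nc1ccc2ncnc(Nc3cccc(C(F)(F)F)c3)c2c1` differs from compound 3 by pyrrolidin-1-yl in place of piperidin-1-yl on a saturated chain carbon bound to an aromatic carbon. Within the data shown here, the one measured step that swaps an amine at that same place, a 1.3-fold lower number from compound 1 to compound 2 (0.12 log units; within the scatter), stayed within the scatter, which is the only guide available; the change from compound 3 to compound 4 is of the same kind. The expected step is therefore a 1.0-fold lower number from compound 3 to compound 4 (0.01 log units; within the scatter), none beyond the scatter. Compound 4 is estimated at 1300 nM, with a range of 650 nM to 2600 nM.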

Compound 4, half-maximal inhibitory concentration: 1230 nM
The estimate for compound 4 lay 1.1-fold (0.02 log units) above the measured number; the range from low to high includes it.
By their numbers in this assay, from the lowest: compounds 2, 4, 3 and 1 (each within the scatter of the next).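

In this assay, replacing the piperidin-1-yl ring with pyrrolidin-1-yl on a saturated chain carbon bound to an aromatic carbon gives a 1.1-fold lower number from compound 3 to compound 4 (0.03 log units; within the scatter) and so, like the earlier dimethylamino swap, leaves the number within the scatter. Moving from 4-((pyrrolidin-1-yl)methyl)phenyl to 3-((pyrrolidin-1-yl)methyl)phenyl on the amide-type nitrogen gives a 1.1-fold lower number from compound 1 to compound 4 (0.04 log units; within the scatter) and is equally unresolved, as is the double change in a 1.2-fold higher number from compound 2 to compound 4 (0.08 log units; within the scatter) on that nitrogen.

Still open, from the compounds shown here alone, is whether a carboxylic acid in place of the (pyrrolidin-1-yl)methyl group, or a longer chain carrying the same amine, would move the number beyond the scatter. Nothing available gives a reason for these results.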